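This account rests on a few compounds, and the source may have more. Where it says the series, first, only, none or still open, it means among the compounds named here.

Compound 1 `O=C(/C=C/c1ccccc1)c1ccc[nH]1` gives in a functional assay on HeLa cells (Homo sapiens) for inhibition, read by MTT assay, with a stated time of 48 h (on this read-out higher numbers stand for weaker inhibition and lower numbers for stronger inhibition), only a limit, > 100000 nM, that is the limit of > 100000 nM in this assay, at which 1 of the 2 values shown sits. Compound 2 `O=C(/C=C/c1ccc(Cl)cc1)c1ccc[nH]1` gives in this assay 25000 nM. Among the compounds with values here, the step of an at least 4.0-fold lower number from compound 1 to compound 2 (0.60 log units; beyond the scatter) is the only measured step. Within the data shown here, compound 2 thus holds the only numerical value in this assay; the other value shown is a limit. Compound 3 `O=C(/C=C/c1ccc(Br)cc1)c1ccc[nH]1` differs from compound 2 by bromo in place of chloro on an aromatic carbon. Among the measured compounds shown here, no measured step exchanges one halogen for another; the single step at hand, an at least 4.0-fold lower number from compound 1 to compound 2 (0.60 log units; beyond the scatter), records a halogen in place of hydrogen on the aromatic carbon and moved the number down, but it does not translate directly to bromo against chloro. For compound 3 the expected step is a 1.4-fold lower number from compound 2 to compound 3 (0.14 log units; within the scatter), within the scatter or a small gain at most. Compound 3 is therefore estimated at 18000 nM, with a range from 7000 nM to 50000 nM.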

Compound 3, half-maximal inhibitory concentration: > 100000 nM
Compound 3 was reported as a limit; the forecaster's own chance of this, stated with the estimate: 10%; at least 5.5-fold (0.74 log units) between middle value and limit.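

In this assay, bromo in place of chloro on the aromatic carbon gives an at least 4.0-fold higher number from compound 2 to compound 3 (0.60 log units; beyond the scatter). The lower number seen with chloro at this position therefore does not carry over to bromo, so the presence of a halogen here is not enough on its own to give a numerical value. The comparison between compound 1 and compound 3 cannot be read because both are limits: the limit of > 100000 nM in this assay, at which 2 of the 3 values shown sit.

From the compounds shown here alone, how far compound 3 lies past its limit stays open, so the true size of the loss from chloro to bromo is unknown. Also open, going by these compounds, is whether fluoro, a methoxy group or an amine at this position would give a numerical value, and whether the chloro result holds up as anything more than a single point.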